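Cytotoxicity notes on the series, compound 4 pending

A few compounds are considered here, and "the series" means these few. Any claim that something is new, unique, unknown or untested is made for them only; others in the source may bear on it.

Measured so far in an ADME assay on 2209-23 cells (Homo sapiens) for cytotoxicity, read by WST assay; on this read-out higher numbers stand for lower toxicity in this test and lower numbers for higher toxicity in this test:
- compound 1 `N#Cc1ccc2c(c1)S(=O)(=O)C=C(c1c(O)c3cc(F)ccc3n(Cc3ccc(F)cc3)c1=O)N2`: compound 1 gives > 50000 nM, a limit of the assay.
- compound 2 `CS(=O)(=O)Nc1ccc2c(c1)S(=O)(=O)C=C(c1c(O)c3cc(F)ccc3n(Cc3ccc(F)cc3)c1=O)N2`: compound 2 gives > 50000 nM, a limit of the assay.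
- compound 3 `CS(=O)(=O)Nc1ccc2c(c1)S(=O)(=O)C=C(c1c(O)c3cc(Cl)ccc3n(Cc3ccc(F)cc3)c1=O)N2`: compound 3 gives > 50000 nM, a limit of the assay.

Compound 3 therefore stands at the upper edge of what this assay reports, a limit rather than a number, as summarised in the limit of > 50000 nM in this assay, at which 3 of the 3 values shown sit. The two single-point steps among the measured compounds, a step that the two limits leave unreadable from compound 1 to compound 2 and a step that the two limits leave unreadable from compound 2 to compound 3, cannot be sized, since both ends sit at the same limit.

The next change is methoxy in place of chloro on an aromatic carbon, giving compound 4 `COc1ccc2c(c1)c(O)c(C1=CS(=O)(=O)c3cc(NS(C)(=O)=O)ccc3N1)c(=O)n2Cc1ccc(F)cc1`. Neither measured step bears readably on it; all that can be said is that the two other single-point changes left the read-out at its limit. For compound 4 the expectation is accordingly a step that the limit leaves unreadable from compound 3 to compound 4, no readable shift beyond the scatter. Compound 4 is estimated at 80000 nM, with a range from 30000 nM to 250000 nM, most likely reported again only as a limit.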

Compound 4, half-maximal cytotoxic concentration: > 50000 nM
Compound 4: no number, only a limit; the forecaster's own chance of this, stated with the estimate: 85%; the middle value does not contradict the limit.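

In this assay compound 4 gives only a limit, and the steps to it from compound 2 and compound 3 cannot be read: the limit of > 50000 nM in this assay, at which 4 of the 4 values shown sit. The compounds shown leave open whether any of these single-point changes moves the half-maximal cytotoxic concentration at all.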